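Three Substituents, One Value: Approaching Compound 4

This account rests on a few compounds, and the source may have more. Where it says the series, first, only, none or still open, it means among the compounds named here.

Measured in a functional assay on DWD cells (Homo sapiens) for inhibition, read by sulforhodamine B assay; a lower number here means a stronger inhibitor of growth, a higher number a weaker inhibitor of growth:
Compound 1 `FC(F)(F)c1ccc(-c2ccc(-c3ccc(-c4nc5ccccc5[nH]4)cc3)cc2)cc1`: 100000 nM
Compound 2 `COc1ccc(-c2ccc(-c3ccc(-c4nc5ccccc5[nH]4)cc3)cc2)cc1`: 100000 nM
Compound 3 `CN(C)c1ccc(-c2ccc(-c3ccc(-c4nc5ccccc5[nH]4)cc3)cc2)cc1`: 100000 nM

Compound 3 stands level with the other two, with no separation among the three values. Compound 4 `COc1ccc(-c2ccc(-c3ccc(-c4nc5ccccc5[nH]4)cc3)cc2)cc1OC` differs from it as follows: 3,4-dimethoxyphenyl in place of 4-(dimethylamino)phenyl on an aromatic carbon. Within the data shown here, three measured steps bear on this change: no change at the digits printed from compound 1 to compound 2 (within the scatter), no change at the digits printed from compound 1 to compound 3 (within the scatter) and no change at the digits printed from compound 2 to compound 3 (within the scatter). Among the measured compounds shown here, none of them moved the value, but no measured compound carries the 3,4-dimethoxyphenyl group. On these steps, no shift beyond the scatter is expected in this assay. The estimated step is no change at the digits printed from compound 3 to compound 4 (within the scatter). The expected value for compound 4 is 100000 nM, with an estimated range from 40000 nM to 100000 nM.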

Compound 4, concentration for 50% growth inhibition: 42100 nM
Beside the measured number, compound 4's estimate is 2.4-fold (0.38 log units) above it, and the stated range covers the measured number.
By their numbers in this assay, from the lowest: compound 4; then compounds 1, 2 and 3 (each within the scatter of the next).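

Putting methoxy in place of hydrogen on an aromatic carbon gave the first separation seen in this assay (a 2.4-fold lower number from compound 2 to compound 4 (0.38 log units; beyond the scatter)), whereas the swaps among single substituents had moved nothing. The 3,4-dimethoxyphenyl group also separates from the other two end groups (a 2.4-fold lower number from compound 3 to compound 4 (0.38 log units; beyond the scatter); a 2.4-fold lower number from compound 1 to compound 4 (0.38 log units; beyond the scatter)). No available evidence accounts for this modest shift. As far as these compounds go, it remains open whether a hydroxyl, an amine or a longer alkoxy chain in place of the added methoxy would lower the number further, and whether the added methoxy would have the same effect without the original one.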